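The source may report more compounds than this note shows. Statements on the series, on what has been measured and on what is new or still open speak of the compounds shown alone.

Compound 1 `Nc1ccccc1NC(=O)c1ccc(CSc2cccc(F)c2)cc1`: 76.3%
Compound 2 `Nc1ccccc1NC(=O)c1ccc(CSc2ccc(Br)cc2)cc1`: 6.17%
Compound 3 `Nc1ccccc1NC(=O)c1ccc(CSCCc2ccccc2)cc1`: not yet measured

In a functional assay on A-375 cells (Homo sapiens) for inhibition, read by CCK-8 assay, with a stated time of 72 h, tested at 8 uM (on this read-out lower numbers stand for less inhibition of growth and higher numbers for more inhibition of growth at the one concentration tested), compound 2 stands lowest of the two measured compounds, at 6.17%. The next change gives compound 3, with phenethyl in place of 4-bromophenyl on a sulfur. Among the measured compounds shown here, one measured step bears on it: a number 70.1 percentage points lower from compound 1 to compound 2 (beyond the scatter), a large step, with 4-bromophenyl in place of 3-fluorophenyl on a sulfur. That step shows that the read-out can move widely when the group on this sulfur changes. For the measured compounds named here, no measured compound carries phenethyl, so the data do not fix the direction. With compound 2 at 6.17%, little room remains downward, so a moderate to large upward step is expected, though with wide uncertainty. The expected step is a number 31.8 percentage points higher from compound 2 to compound 3 (beyond the scatter). For compound 3 the estimate is 38%, with an expected range of 8% to 78%.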

Compound 3, percent growth inhibition at one concentration: 69.9%
Compound 3: the middle estimate sits 31.9 percentage points below what was measured; the range from low to high includes it.
By their numbers in this assay, from the lowest: compound 2; then compounds 3 and 1 (each within the scatter of the next).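

In this assay, the low reading of compound 2 does not extend to every group on this sulfur: the change to phenethyl gives a number 63.7 percentage points higher from compound 2 to compound 3 (beyond the scatter), which nearly spans the earlier drop. The other comparison gives a number 6.4 percentage points lower from compound 1 to compound 3 (within the scatter), so a ring held on a saturated chain and a 3-fluorophenyl ring directly on the sulfur read alike, and among these three compounds only the 4-bromophenyl compound stands apart. No available measurement explains the separate reading of compound 2.

As far as these compounds go, whether 4-fluorophenyl or 3-bromophenyl on this sulfur would read with compound 1 or with compound 2 remains open, so the halogen and its ring position cannot yet be separated. Also open, from the compounds shown here alone, is how an amine or a carboxylic acid on a longer chain at this sulfur would read.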